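The compounds below may be only part of what the source reports. "The series", "measured", "known", "first", "only" and "open" are said of these compounds alone.

In a functional assay on MCF7 cells (Homo sapiens) for cytotoxicity, read by MTT assay (a higher number here means a weaker inhibitor, a lower number a stronger inhibitor), three compounds have been measured. Compound 1 (`COc1ccc(C#Cc2cc(OC)c(OC)c(OC)c2)cc1O`) gives 1640 nM in this test, compound 2 (`COCOc1cc(/C=C\c2cc(OC)c(OC)c(OC)c2)ccc1OC`) gives 269 nM, and compound 3 (`COc1ccc(C2CC2c2cc(OC)c(OC)c(OC)c2)cc1OP(=O)(O)O`) gives 297 nM. Compound 3 thus stands level with compound 2, the two lying within the scatter of each other, while compound 1 has a clearly higher number than compound 3, beyond the scatter.

Compound 4 (`COc1ccc(C2CC2c2cc(OC)c(OC)c(OC)c2)cc1N`) keeps the shared core of compound 3 and differs from it in one place (one nitrogen atom in place of a group of 5 heavy atoms (4 oxygen, 1 phosphorus; no ring), on an aromatic carbon): one nitrogen atom in place of a group of 5 heavy atoms, on an aromatic carbon. The entering group is an amino group. Among the measured compounds shown here, no pair of measured compounds differs in only one place, so nothing measured shows this change directly, and the expectation remains loose. It starts from compound 3 at 297 nM and allows for the spread seen in this small set, which includes compound 1 at 1640 nM in this assay.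

A modest move toward a lower number is expected, with the estimated step being a 2.1-fold lower number from compound 3 to compound 4 (0.33 log units; beyond the scatter) and lying near the edge of the scatter. For compound 4 the expected value is 140 nM as a middle figure, with an estimated range from 30 nM to 700 nM for repeated measurements.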

Compound 4, half-maximal inhibitory concentration: 212 nM
The estimate for compound 4 lay 1.5-fold (0.18 log units) below the measured number, and the stated range covers the measured number.
By their numbers in this assay, from the lowest: compounds 4, 2 and 3 (each within the scatter of the next); then compound 1.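

Among the compounds shown here, at the aromatic carbon ortho to a methoxy group and meta to a large group, the exchange of the group of 5 heavy atoms for an amino group amounts to a 1.4-fold lower number from compound 3 to compound 4 (0.15 log units; within the scatter) in this assay and is the first change in this set that can be read at a single place. For this one pair, then, going from the larger group with phosphorus to a single nitrogen atom leaves the number level, and the position accepts both groups without a difference that can be told from the scatter. Nothing measured here accounts for this result.

The compounds shown leave open whether other groups at this same place, such as an acetamide, a carboxylic acid or a fluorine atom, would also stay level with the amino group in this assay or would move the number clearly. They also leave open whether the same exchange would give a similar step on a core other than that of compound 3, since this single pair is the only one that speaks to it.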